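The source may report more compounds than this note shows. Statements on the series, on what has been measured and on what is new or still open speak of the compounds shown alone.

Compound 1, `O=C1C2=C(C(=O)c3ncccc31)C1(CS2)NC(=O)N(c2ccc([N+](=O)[O-])cc2)C1=O`, gives 250 nM in a functional assay on HT-29 cells (Homo sapiens) for antiproliferative activity, read by MTT assay, with a stated time of 96 h; a lower number here means a stronger inhibitor, a higher number a weaker inhibitor.
Compound 2, `Cc1ccc(N2C(=O)NC3(CSC4=C3C(=O)c3ncccc3C4=O)C2=O)cc1`, gives 1 nM in this assay.
Compound 3, `CCCCCc1ccc(N2C(=O)NC3(CSC4=C3C(=O)c3ncccc3C4=O)C2=O)cc1`, gives 250 nM in this assay.

Compound 3 stands level with compound 1 at the digits shown, and the two together give the highest numbers of the three in this assay. Compound 2 is the furthest away from compound 3: the step of a 250-fold higher number from compound 2 to compound 3 (2.40 log units; beyond the scatter) is large and well beyond the scatter.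

Compound 4, `CCCCc1ccc(N2C(=O)NC3(CSC4=C3C(=O)c3ncccc3C4=O)C2=O)cc1`, has not yet been measured. It differs from compound 3 in one place: hydrogen in place of methyl on a saturated chain carbon, four bonds along the chain from an aromatic carbon. The pentyl of compound 3 thus becomes a butyl, a single carbon back toward the methyl of compound 2.

For the measured compounds named here, three measured steps bear on this. a 250-fold higher number from compound 2 to compound 3 (2.40 log units; beyond the scatter) shows that extending methyl to pentyl raises the number greatly. a 250-fold lower number from compound 1 to compound 2 (2.40 log units; beyond the scatter) and no change at the digits printed from compound 1 to compound 3 (within the scatter) show that only the methyl compound stands apart, while nitro and pentyl sit together. Going by the values given here, no measured pair tells where along the chain the change happens, so only a partial move toward compound 2 is expected. Compound 4 is therefore expected to give 60 nM in this assay, between 5 nM and 400 nM. The expected step would be a 4.2-fold lower number from compound 3 to compound 4 (0.62 log units; beyond the scatter), a moderate lowering.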

Compound 4, half-maximal inhibitory concentration: 50 nM
Estimate against measurement, compound 4: 1.2-fold (0.08 log units) above; the measured number falls inside the stated range.
By their numbers in this assay, from the lowest: compound 2; then compound 4; then compounds 1 and 3 (each within the scatter of the next).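

In this assay, for the compounds shown here, the methyl that sits on a saturated chain carbon, four bonds along the chain from an aromatic carbon, proves to matter: its replacement by hydrogen gives a 5.0-fold lower number from compound 3 to compound 4 (0.70 log units; beyond the scatter) and is the first step to show that a change of a single carbon in this chain can be read beyond the scatter. The butyl compound nevertheless remains far from the methyl compound, with a 50-fold higher number from compound 2 to compound 4 (1.70 log units; beyond the scatter) against only a modest step from butyl to pentyl, so across these three compounds the larger part of the rise lies between methyl and butyl. The earlier compounds shown here placed nitro and pentyl together, but a 5.0-fold lower number from compound 1 to compound 4 (0.70 log units; beyond the scatter) sets the butyl compound apart from nitro as well, so the series now holds three distinct levels rather than the methyl compound alone against the other two.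

Nothing offered here accounts for the way the number follows chain length. Where the climb from methyl to butyl takes place remains open, as an ethyl or propyl chain would be needed to place it, and so does whether a longer chain than pentyl, or an amine at the far end of the chain, would follow the same course.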